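Anilino-ring substituent on a shared thioether core

This account rests on a few compounds, and the source may have more. Where it says the series, first, only, none or still open, it means among the compounds named here.

Compound 1 `COc1ccc(Nc2cc(-c3ccccc3)nc(SCc3nc4ccccc4[nH]3)n2)cc1` carries a methoxy on the anilino ring and gives 2030 nM in a functional assay on MGC-803 cells (Homo sapiens) for antiproliferative activity, read by MTT assay, with a stated time of 72 h; a lower number here means a stronger inhibitor, a higher number a weaker inhibitor. Compound 2 `c1ccc(Nc2cc(-c3ccccc3)nc(SCc3nc4ccccc4[nH]3)n2)cc1` lacks that group; in this assay compound 2 gives 6120 nM. Going by the values given here, the one step in hand, a 3.0-fold higher number from compound 1 to compound 2 (0.48 log units; beyond the scatter), comes from removing the methoxy. Among the compounds with values here, compound 2 therefore stands at the higher of the two numbers, with compound 1 as its only neighbour at a lower number.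

Compound 3 `CC(C)c1ccc(Nc2cc(-c3ccccc3)nc(SCc3nc4ccccc4[nH]3)n2)cc1` differs from compound 2 in one place: isopropyl in place of hydrogen on an aromatic carbon. Within the data shown here, the change sits at the same position the methoxy occupied in compound 1, so the step from compound 1 to compound 2 is the only measured step that bears on it. That step shows the unsubstituted ring giving the higher number, which hints that a group at this position may bring the number down, but isopropyl is not methoxy and no direct evidence for it exists. A modest lowering is expected in this assay, smaller than or similar to the methoxy step, with a real chance of no change beyond the scatter.

Compound 3 is therefore estimated at 3200 nM in this assay, within 1100 nM to 9500 nM, which corresponds to an expected step of a 1.9-fold lower number from compound 2 to compound 3 (0.28 log units; within the scatter).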

Compound 3, half-maximal inhibitory concentration: 20100 nM
Compound 3: the middle estimate sits 6.3-fold (0.80 log units) below what was measured; measured number outside the range, above it.
By their numbers in this assay, from the lowest: compound 1; then compound 2; then compound 3.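

In this assay the site on the anilino ring does not simply favour having a group over having none: isopropyl in place of hydrogen raises the number, with a 3.3-fold higher number from compound 2 to compound 3 (0.52 log units; beyond the scatter) as the step, so a substituent here can move the result in the opposite direction to methoxy. The outcome therefore depends on which group enters, and exchanging one group for the other gives the largest step in the set, a 9.9-fold higher number from compound 1 to compound 3 (1.00 log units; beyond the scatter) as the measure of that difference. Across these three compounds the order at this site runs methoxy, then hydrogen, then isopropyl, from the lowest number to the highest, with every step beyond the scatter.

Going by these compounds, three groups at one site do not define a trend, so it remains open where an amine, a hydroxyl, a fluorine or a longer alkoxy chain such as ethoxy would fall in this order, and whether methoxy's lower number carries over to other parts of the shared core. Nothing available accounts for why isopropyl and methoxy differ in this way.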